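Compound 3 to compound 4: an aryl swap on sulfur

A few compounds are considered here, and "the series" means these few. Any claim that something is new, unique, unknown or untested is made for them only; others in the source may bear on it.

Compound 1 `O=[N+]([O-])c1cccc2c1CCN(c1ncnc3c1ncn3[C@@H]1O[C@H](CO)[C@@H](O)[C@H]1O)C2`: 3020 nM
Compound 2 `OC[C@H]1O[C@@H](n2cnc3c(SCCCc4ccccc4)ncnc32)[C@H](O)[C@@H]1O`: 1350 nM
Compound 3 `Cc1cc(C)c(SCc2ncnc3c2ncn3[C@@H]2O[C@H](CO)[C@@H](O)[C@H]2O)c(C)c1`: 33100 nM

In an assay on isolated protein for binding affinity to Equilibrative nucleoside transporter 1 (Homo sapiens) (on this read-out higher numbers stand for weaker inhibition and lower numbers for stronger inhibition), compound 3 gives the highest of the three numbers; the nearest is compound 1, whose value lies beyond the scatter below it, and the furthest is compound 2, further below it still. Compound 4 `OC[C@H]1O[C@@H](n2cnc3c(CSc4ccc(I)cc4)ncnc32)[C@H](O)[C@@H]1O` has not been measured in this assay. It differs from compound 3 in one place: 4-iodophenyl in place of 2,4,6-trimethylphenyl on a sulfur. Among the measured compounds shown here, no measured pair shows this change, so its size is open. The expectation is a modest move toward a lower number, beyond the scatter, since compound 2 shows that a sulfur-linked group on this core can reach 1350 nM. Compound 4 is estimated at 9000 nM, with a range of 2500 nM to 30000 nM, a step of a 3.7-fold lower number from compound 3 to compound 4 (0.57 log units; beyond the scatter).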

Compound 4, half-maximal inhibitory concentration: 69.2 nM
Compound 4: middle estimate off by 130-fold (2.11 log units), on the high side; measured number outside the range, below it.
By their numbers in this assay, from the lowest: compound 4; then compound 2; then compound 1; then compound 3.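

In this assay, 4-iodophenyl in place of 2,4,6-trimethylphenyl on a sulfur gives a 480-fold lower number from compound 3 to compound 4 (2.68 log units; beyond the scatter), a large step that places compound 4 lowest of the four by number. It shows that the aryl group on this sulfur, whose other neighbour is a saturated chain carbon, can alone shift the read-out strongly. Nothing measured here accounts for the step. The compounds shown leave open whether the iodine or the absence of the three methyl groups carries this change. On these data alone, whether 4-bromophenyl or plain phenyl on the same sulfur would keep the low number also remains open.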